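The compounds below may be only part of what the source reports. "The series", "measured", "known", "first", "only" and "open" are said of these compounds alone.

Working notes on the series. Compound 1 `CC#CCn1c(N2CCC[C@@H](N)C2)nc2c1c(=O)n(Cc1c(Cl)cccc1C(=O)OC)c(=O)n2C`, compound 2 `CC#CCn1c(N2CCC[C@@H](N)C2)nc2c1c(=O)n(Cc1cc(OC)ccc1C(=O)O)c(=O)n2C` and compound 3 `CC#CCn1c(N2CCC[C@@H](N)C2)nc2c1c(=O)n(Cc1c(Cl)cccc1C(=O)O)c(=O)n2C` share one core and differ only in the substituted phenyl group attached to it. In an ADME assay on isolated protein for inhibition of Dipeptidyl peptidase 9 (Homo sapiens), with stated times of 15 min, 60 s and 20 min (a higher number here means a weaker inhibitor, a lower number a stronger inhibitor), compound 1 gives > 100000 nM, which is a limit of the assay and not a number. In this assay compound 2 gives > 100000 nM, likewise a limit. Compound 3 gives > 100000 nM in this assay, again only a limit, so compound 3 stands at the edge of what the assay reports rather than at a measured point. The steps a step that the two limits leave unreadable from compound 1 to compound 2, a step that the two limits leave unreadable from compound 1 to compound 3 and a step that the two limits leave unreadable from compound 2 to compound 3 cannot be read in size or direction, since all three values sit at the limit of > 100000 nM in this assay, at which 3 of the 3 values shown sit.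

Compound 4 `CC#CCn1c(N2CCC[C@@H](N)C2)nc2c1c(=O)n(Cc1c(OC)cccc1C(=O)O)c(=O)n2C` is not yet measured. It differs from compound 3 by methoxy in place of chloro on an aromatic carbon. Within the data shown here, no measured step bears on this change with a readable size, so nothing in the three compounds points to movement beyond the scatter in this assay in either direction. Because every neighbour of compound 4 sits at the limit of > 100000 nM in this assay, at which 3 of the 3 values shown sit, compound 4 is expected to report a limit as well. The expected step of a number no higher from compound 3 to compound 4 (the limit leaves the size open) is therefore estimated as none beyond the scatter. Compound 4 is expected at about 100000 nM, with a range from 30000 nM to 300000 nM.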

Compound 4, half-maximal inhibitory concentration: > 100000 nM
Compound 4: no number, only a limit (the forecaster's own chance of this, stated with the estimate: 85%); the middle value lies on the limit itself.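

In this assay compound 4 gives > 100000 nM, which is a limit and not a number. The steps linking compound 1, compound 2 and compound 3 to compound 4 cannot be read in size or direction: the limit of > 100000 nM in this assay, at which 4 of the 4 values shown sit. The compounds shown leave open how far each lies past that limit, and whether any substituted phenyl group gives a readable value in this assay.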